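This account rests on a few compounds, and the source may have more. Where it says the series, first, only, none or still open, it means among the compounds named here.

Of the compounds shown here, two have so far been measured in a functional assay on A549 cells (Homo sapiens) for inhibition, read by sulforhodamine B assay, tested at 10 uM; a lower number here means less inhibition of growth, a higher number more inhibition of growth at the concentration tested. Compound 1, `CC(=O)N1N=C(c2ccc(OCc3cn(Cc4ccc([N+](=O)[O-])cc4)nn3)cc2)CC1c1ccccc1`, gives 15% in this assay. Compound 2, `COc1cc(C2CC(c3ccc(Br)cc3)=NN2C(C)=O)ccc1OCc1cn(Cc2ccc([N+](=O)[O-])cc2)nn1`, gives 0% in this assay; this is the lowest of the two numbers, and compound 1 stands higher by a margin beyond the usual scatter of repeated measurements. Compound 3, `COc1cc(C2CC(c3cccc4ccccc34)=NN2C(C)=O)ccc1OCc1cn(Cc2ccc([N+](=O)[O-])cc2)nn1`, has not yet been measured. It differs from compound 2 in one place: naphthalen-1-yl in place of 4-bromophenyl on a carbon with a double bond to nitrogen. Among the compounds with values here, no pair of measured compounds shows this particular change, so there is no measured step to lean on, and the two measured compounds give no other hint of how such a change acts. Within the data shown here, with compound 2 at the floor of the scale and only one other number known, a shift of a size beyond the scatter cannot be anticipated in either direction. The step from compound 2 to compound 3 is therefore expected to be a number 8 percentage points higher from compound 2 to compound 3 (within the scatter), which is none beyond the scatter. Compound 3 is accordingly estimated at 8%, with a range from 0% to 25%.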

Compound 3, percent growth inhibition at one concentration: 89%
Compound 3: middle estimate off by 81 percentage points, on the low side, outside the stated range (above it).
By their numbers in this assay, from the lowest: compound 2; then compound 1; then compound 3.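

Replacing 4-bromophenyl with naphthalen-1-yl on a carbon with a double bond to nitrogen gives a number 89 percentage points higher from compound 2 to compound 3 (beyond the scatter) in this assay. This shows that a single change at this position, two ring bonds from the ring atom that bears an acetyl group, can carry the read-out from the floor of the scale to a high level of growth inhibition, something the earlier pair could not show, as those two compounds differ in more than one place. The step trades one six-membered aromatic ring of carbon only, with its bromine, for two such rings, yet nothing available here bears on what lies behind the jump.

Still open, on these data alone, is whether the rise comes with the second aromatic ring or with the loss of bromine, as both happen in this one step, and a plain phenyl at this position would help to tell the two apart. As far as these compounds go, it is also open how far this position tolerates other kinds of group, such as an amine or a carboxylic acid on the naphthalen-1-yl.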